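A New Side Chain on the Shared Core

The source may hold more compounds than are shown below. What is called first, only, known or untested is meant among the compounds shown, and "the series" means these compounds.

Three compounds share a core that carries two 4-methoxyphenyl groups and differ only in the group on the aromatic carbon of the five-membered aromatic ring with 1 nitrogen and 1 sulfur. Compound 1 `COc1ccc(-c2nc(CN(C)C)sc2-c2ccc(OC)cc2)cc1` carries a (dimethylamino)methyl group there, and in a functional assay with Oryctolagus cuniculus as the target (a higher number here means a weaker inhibitor, a lower number a stronger inhibitor), compound 1 gives 96 nM. Compound 2 `COc1ccc(-c2nc(C(=O)N3CCCCC3CCO)sc2-c2ccc(OC)cc2)cc1` carries an amide instead, and in this assay compound 2 gives 45 nM. Compound 3 `COc1ccc(-c2nc(C(=O)N3CCNC(CCO)C3)sc2-c2ccc(OC)cc2)cc1` reaches only a limit in this assay, > 1000 nM, so no number is known for it. Among the compounds with values here, of the two known numbers compound 1 stands highest, with compound 2 nearest and the gap between them beyond the scatter.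

Within the data shown here, the only measured step, an at least 22-fold higher number from compound 2 to compound 3 (1.34 log units; beyond the scatter), shows that exchanging one ring amide for another at this position can change the number greatly. Compound 4 `CCOC(=O)/C(C#N)=C/c1nc(-c2ccc(OC)cc2)c(-c2ccc(OC)cc2)s1` changes the same position in a different way: 2-cyano-2-(ethoxycarbonyl)ethenyl in place of (dimethylamino)methyl on an aromatic carbon. Among the measured compounds shown here, no measured step exchanges an amine for an unsaturated ester bearing a nitrile, so the direction of this change cannot be read from the data, and only a wide expectation can be given. The step of a 2.1-fold higher number from compound 1 to compound 4 (0.32 log units; beyond the scatter) is expected to be modest, with the number for compound 4 estimated at 200 nM, between 40 nM and 1500 nM.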

Compound 4, half-maximal inhibitory concentration: < 10 nM
Compound 4 was reported as a limit; the forecaster's own chance of this, stated with the estimate: 25%; middle value at least 20-fold (1.30 log units) away from the limit.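

Exchanging (dimethylamino)methyl for 2-cyano-2-(ethoxycarbonyl)ethenyl on this aromatic carbon gives an at least 9.6-fold lower number from compound 1 to compound 4 (0.98 log units; beyond the scatter) in this assay, so a group with no amine and no amide can sit at this position and still give a lower number than compound 1. The earlier step at this position went only towards a higher number, and this one shows that changing the same position can also move the number the other way, by a margin beyond the usual scatter. The printed step gives only a bound on the real size of the change because compound 4 is reported as a limit and not as a number: the limit of < 10 nM in this assay, at which 1 of the 4 values shown sits.

The compounds shown leave open which part of the new group matters, as the double bond, the nitrile and the ethyl ester all enter together in compound 4. A carboxylic acid in place of the ethyl ester, or a simple ethenyl chain carrying neither the nitrile nor the ester, would help separate these parts and show how much each one contributes in this assay.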